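This account rests on a few compounds, and the source may have more. Where it says the series, first, only, none or still open, it means among the compounds named here.

Compound 1, with the structure `C=C[C@@](C)(/C=C/c1ccc(Nc2ccccc2)cc1)CCC=C(C)C`, has been tested in a functional assay on HepG2 cells (Homo sapiens) for cytotoxicity, with a stated time of 72 h; on this read-out lower numbers stand for an effect already at smaller amounts and higher numbers for an effect only at larger amounts of compound. In this assay compound 1 gives > 52000 nM, which is a limit of the assay and not a number. Compound 2, with the structure `C=C[C@@](C)(/C=C/c1ccc(Nc2ccc(C(F)(F)F)cc2)cc1)CCC=C(C)C`, carries a trifluoromethyl in place of hydrogen on an aromatic carbon. In this assay compound 2 gives > 52000 nM, again a limit rather than a number. The step that the two limits leave unreadable from compound 1 to compound 2 therefore cannot be read, because of the limit of > 52000 nM in this assay, at which 2 of the 2 values shown sit.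

Compound 3, with the structure `C=C[C@@](C)(/C=C/c1ccc(-c2ccc(Cl)cc2)cc1)CCC=C(C)C`, differs from compound 1 by 4-chlorophenyl in place of anilino on an aromatic carbon. Going by the values given here, no measured step bears directly on this change, since the only step on record could not be sized. Compound 3 is therefore expected to behave much like compound 1, with the step of a number no higher from compound 1 to compound 3 (the limit leaves the size open) expected to lie within the scatter. Compound 3 is estimated at 52000 nM, between 15000 nM and 200000 nM.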

Compound 3, half-maximal effective concentration: > 52000 nM
Compound 3: only a limit was reported; the forecaster's own chance of this, stated with the estimate: 70%; the middle value sits exactly at the limit.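

In this assay compound 3 again gives only a limit and not a number, as compound 1 does, so no step between compound 1 and compound 3 can be read: the limit of > 52000 nM in this assay, at which 3 of the 3 values shown sit.

The compounds shown leave open what amount of any of them produces an effect in this assay, and whether swapping anilino for 4-chlorophenyl changes that amount at all.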